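This account rests on a few compounds, and the source may have more. Where it says the series, first, only, none or still open, it means among the compounds named here.

Measured compounds:
- compound 1 `CCCC(C)n1c(CC)nc2c(-c3ccc(OC)nc3C(F)(F)F)ccnc21`: 0.6 nM
- compound 2 `CCc1nc2c(-c3ccc(OC)nc3C(F)(F)F)ccnc2n1C(C)C1CCC1`: 0.8 nM

Two compounds share one core and were tested in an assay for binding affinity to Corticotropin releasing factor receptor (Rattus norvegicus); on this read-out higher numbers stand for weaker inhibition and lower numbers for stronger inhibition. Compound 1 gives 0.6 nM and compound 2 gives 0.8 nM; the step of a 1.3-fold higher number from compound 1 to compound 2 (0.12 log units; within the scatter) is within the scatter, so the two cannot be told apart on these numbers. That step swaps a cyclobutyl for a propyl on a saturated chain carbon bound to an aromatic nitrogen and a saturated chain carbon.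

Compound 3 `CCCC(C)n1c(CC)nc2c(-c3ccc(OCCO)nc3C(F)(F)F)ccnc21` changes a different part of compound 1: hydroxymethyl in place of hydrogen on a saturated chain carbon bound to an oxygen on an aromatic ring. Put another way, the methoxy becomes a 2-hydroxyethoxy. Among the measured compounds shown here, no measured step touches this group, so the only measured step, from compound 1 to compound 2, bears on it only indirectly, by showing that a change at one edge of the molecule left this assay unmoved. For the measured compounds named here, with no direct precedent, the expectation is that the step of a 2.0-fold higher number from compound 1 to compound 3 (0.30 log units; within the scatter) stays within the scatter or is modest. Compound 3 is therefore estimated at 1.2 nM, with a range from 0.3 nM to 5 nM.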

Compound 3, inhibition constant: 10.1 nM
Compound 3: the middle estimate sits 8.4-fold (0.93 log units) below what was measured, and the stated range ends below it.
By their numbers in this assay, from the lowest: compounds 1 and 2 (each within the scatter of the next); then compound 3.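

In this assay, turning the methoxy of compound 1 into the 2-hydroxyethoxy of compound 3 gives a clear change (a 17-fold higher number from compound 1 to compound 3 (1.23 log units; beyond the scatter)), so the saturated chain carbon bound to an oxygen on an aromatic ring is a place where this assay responds to a small addition of 2 heavy atoms. The earlier pair could not show this: its step (a 1.3-fold higher number from compound 1 to compound 2 (0.12 log units; within the scatter)) lies within the scatter and concerns a different place, so a change at one place that leaves the number unmoved says little about another place on the same molecule. Among the compounds shown here, nothing available here explains why this hydroxymethyl raises the number so far.

The compounds shown leave open whether the step follows from the longer chain, from the hydroxyl at its end, or from both, and a plain ethoxy, a 2-methoxyethoxy or a 2-aminoethoxy at this place would help separate those readings. Also open, on these data alone, is whether the same addition would move the number by a similar amount on the cyclobutyl-bearing compound 2, since one step on one compound cannot establish a general rule.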